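From compound 2 to its free amino relative

The source may report more compounds than this note shows. Statements on the series, on what has been measured and on what is new or still open speak of the compounds shown alone.

In a functional assay on A549 cells (Homo sapiens) for inhibition, read by MTT assay (a lower number here means a stronger inhibitor, a higher number a weaker inhibitor), compound 1 `CCOC(=O)c1c(N)sc(C(=O)Nc2ccc(Cl)cc2)c1-c1ccccc1` gives 230 nM and compound 2 `CCOC(=O)c1c(NC(=O)CC#N)sc(C(=O)Nc2ccccc2)c1-c1ccccc1` gives 320 nM. These two numbers lie within the scatter of each other, so on the evidence so far compound 2 stands level with compound 1.

Compound 3 `CCOC(=O)c1c(N)sc(C(=O)Nc2ccccc2)c1-c1ccccc1` has not yet been measured. It comes from compound 2 through a single structural change, with hydrogen in place of (cyanomethyl)carbonyl on a nitrogen on an aromatic ring. The side chain on that nitrogen is removed, and a plain amino group remains.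

Among the measured compounds shown here, no measured pair of compounds shows this change on its own, so its effect in this assay cannot be read directly. Compound 1 also carries a plain amino group and gives 230 nM, close to the number for compound 2, so no large move in either direction is expected. The expected size of the change is small, with a 1.1-fold higher number from compound 2 to compound 3 (0.04 log units; within the scatter), which would stay within the scatter. For compound 3 the estimated value is 350 nM, with an expected range of 120 nM to 1000 nM.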

Compound 3, half-maximal inhibitory concentration: 6800 nM
Compound 3: middle estimate off by 19-fold (1.29 log units), on the low side; measured number outside the range, above it.
By their numbers in this assay, from the lowest: compounds 1 and 2 (each within the scatter of the next); then compound 3.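

In this assay, taking the (cyanomethyl)carbonyl off the nitrogen on the aromatic ring gives a 21-fold higher number from compound 2 to compound 3 (1.33 log units; beyond the scatter) and is far from the neutral swap it might have seemed, so on this core that side chain carries much of the inhibition. A plain amino group therefore does not by itself give a low number, since the chloro on an aromatic carbon counts for just as much: hydrogen in its place gives a 30-fold higher number from compound 1 to compound 3 (1.47 log units; beyond the scatter) in this same comparison of near neighbours. Compound 3 is thus the weakest of the three, each of the other two differs from it in one place only, and nothing measured here gives a reason for either step.

As far as these compounds go, it stays open whether the nitrile itself matters or whether a simple acetyl group, or a longer chain ending in a carboxylic acid, would serve as well on that nitrogen. From the compounds shown here alone, it also stays open whether fluoro or methoxy could stand in for chloro, and whether chloro and the (cyanomethyl)carbonyl together would lower the number further.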